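Amide carbonyl substituent step in the shared-core series

The compounds below may be only part of what the source reports. "The series", "measured", "known", "first", "only" and "open" are said of these compounds alone.

Compound 1 `Cc1nc(S(C)(=O)=O)ccc1Oc1ncnc(OC2CCN(C(=O)C3CCCC3)CC2)c1F` gives 72.8 nM in a functional assay on isolated protein for inhibition of Glucose-dependent insulinotropic receptor (Homo sapiens), read by HTRF and cAMP accumulation; on this read-out lower numbers stand for an effect already at smaller amounts and higher numbers for an effect only at larger amounts of compound. Among the measured compounds shown here, compound 2 `Cc1nc(S(C)(=O)=O)ccc1Oc1ncnc(OC2CCN(C(=O)C3(C)CC3)CC2)c1F` gives 761 nM in this assay, the highest of the two numbers; the only measured step is a 10-fold higher number from compound 1 to compound 2 (1.02 log units; beyond the scatter). Compound 3 `Cc1nc(S(C)(=O)=O)ccc1Oc1ncnc(OC2CCN(C(=O)c3ncc(Cl)cn3)CC2)c1F` carries 5-chloropyrimidin-2-yl in place of 1-methylcyclopropyl on a carbonyl carbon. For the measured compounds named here, no measured step covers an aromatic group on this carbonyl carbon; the single measured step, from a larger carbocycle to a smaller one, went toward a higher number, so a return to a larger group is expected to bring the number down, with the size of that drop uncertain. Compound 3 is therefore expected at 120 nM, within 25 nM to 600 nM, an expected step of a 6.3-fold lower number from compound 2 to compound 3 (0.80 log units; beyond the scatter).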

Compound 3, half-maximal effective concentration: 6.12 nM
For compound 3 the middle estimate is 20-fold (1.29 log units) above the measured one; measured number below the stated range.
By their numbers in this assay, from the lowest: compound 3; then compound 1; then compound 2.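

On the carbonyl carbon, 5-chloropyrimidin-2-yl in place of 1-methylcyclopropyl gives a 120-fold lower number from compound 2 to compound 3 (2.09 log units; beyond the scatter) and in place of cyclopentyl gives a 12-fold lower number from compound 1 to compound 3 (1.08 log units; beyond the scatter) so this position accepts an aromatic ring, and that ring gives a lower number than either carbocycle. No measurement shown here accounts for this difference.

Still open, from the compounds shown here alone, is what within 5-chloropyrimidin-2-yl carries the change, since nothing here separates it from phenyl or unsubstituted pyrimidin-2-yl on this carbonyl carbon. Also open, going by these compounds, is how a methoxy or a nitrile in place of the chlorine would read.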